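The compounds below may be only part of what the source reports. "The series", "measured", "known", "first", "only" and "open" are said of these compounds alone.

Going by the values given here, three related compounds have numbers so far in a functional assay on MCF7 cells (Homo sapiens) for antiproliferative activity, read by MTT assay, with a stated time of 72 h; on this read-out higher numbers stand for weaker inhibition and lower numbers for stronger inhibition. Compound 1 `O=S1(=O)C=Cc2ccc(Nc3cccc(OC(F)(F)F)c3)cc21` gives 2020 nM, compound 2 `O=S1(=O)C=Cc2cccc(Nc3ccc(OC(F)(F)F)cc3)c21` gives 2690 nM, and compound 3 `O=S1(=O)C=Cc2cccc(Nc3ccc(C(F)(F)F)cc3)c21` gives 1820 nM. Compound 3 therefore sits level with the other two, since all three numbers lie within the usual scatter of one another.

The next compound, compound 4 `O=S1(=O)C=Cc2cccc(Nc3ccc(Cl)cc3)c21`, differs from compound 3 in a single group: chloro in place of trifluoromethyl on an aromatic carbon. This is chloro in place of trifluoromethyl on an aromatic carbon, para to a large group.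

Among the compounds with values here, only one measured step offers a guide: a 1.5-fold lower number from compound 2 to compound 3 (0.17 log units; within the scatter), where trifluoromethyl took the place of trifluoromethoxy. That step stayed within the scatter. Within the data shown here, no measured compound carries chloro, so this guide is a limited one. A step beyond the scatter in this assay is therefore not expected, in either direction. The expected change is a 1.2-fold higher number from compound 3 to compound 4 (0.08 log units; within the scatter), which is no real shift. For compound 4 the estimated value is 2200 nM, with an expected range from 1000 nM to 5000 nM.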

Compound 4, half-maximal inhibitory concentration: 680 nM
Compound 4: the middle estimate sits 3.2-fold (0.51 log units) above what was measured; measured number outside the range, below it.
By their numbers in this assay, from the lowest: compound 4; then compounds 3, 1 and 2 (each within the scatter of the next).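

At this place, on an aromatic carbon para to a large group, the choice of substituent now visibly matters in this assay: chloro in place of trifluoromethyl brings a 2.7-fold lower number from compound 3 to compound 4 (0.43 log units; beyond the scatter) and so moves the number beyond the scatter. Chloro in place of trifluoromethoxy brings a 4.0-fold lower number from compound 2 to compound 4 (0.60 log units; beyond the scatter) as well, whereas the swap between the two fluorine-bearing groups stayed within the scatter, so among these compounds only chloro stands apart, and by a modest step. Nothing shown explains why this change has that effect.

Still open, on these data alone, is whether other small groups at this place, such as fluoro, bromo, methyl or methoxy, would match compound 4 or differ from it. It is also unknown whether chloro would bring a similar step in the arrangement of compound 1.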